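Isopropyl Added to a Dibrominated Chromone: Expected Growth Inhibition

The source may report more compounds than this note shows. Statements on the series, on what has been measured and on what is new or still open speak of the compounds shown alone.

Compound 1 `Cc1cc(=O)oc2cc(SCc3cccc(C#N)c3)ccc12` in a functional assay on A549 cells (Homo sapiens) for antiproliferative activity, read by sulforhodamine B assay, with a stated time of 72 h; a lower number here means a stronger inhibitor of growth, a higher number a weaker inhibitor of growth: > 32500 nM, a limit of the assay.
Compound 2 `CCc1cc(=O)c2ccc(OC)c(CBr)c2o1` in this assay: > 33600 nM, a limit of the assay.
Compound 3 `COc1ccc2c(=O)cc(C(C)Br)oc2c1CBr` in this assay: > 26500 nM, a limit of the assay.

Going by the values given here, every value measured so far is a limit, meaning none of the three compounds slowed cell growth strongly enough for a number to be reported. Compound 3 stands at the limit of > 26500 nM in this assay, at which 1 of the 3 values shown sits, and the two other values are likewise limits. Among the compounds with values here, the single step between neighbouring compounds, a step that the two limits leave unreadable from compound 2 to compound 3, cannot be read because both of its ends are limits.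

Compound 4 `CC(C)COc1ccc2c(=O)cc(C(C)Br)oc2c1CBr` differs from compound 3 by isopropyl in place of hydrogen on a saturated chain carbon bound to an oxygen on an aromatic ring. Within the data shown here, no measured step bears on this particular change, and the only step available gives no readable size, so there is no ground to expect a shift beyond the usual scatter in this assay. For compound 4 the expected step, a step that the limit leaves unreadable from compound 3 to compound 4, is therefore small. The expectation is that this assay again reports only a limit for compound 4, estimated at 40000 nM, within a range from 15000 nM to 150000 nM.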

Compound 4, concentration for 50% growth inhibition: 8710 nM
Beside the measured number, compound 4's estimate is 4.6-fold (0.66 log units) above it; the whole stated range lies above it.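

Replacing methoxy with isobutoxy, with isopropyl added on the saturated chain carbon bound to an oxygen on an aromatic ring, gives an at least 3.0-fold lower number from compound 3 to compound 4 (0.48 log units; beyond the scatter) in this assay, so this is the first change among the compounds shown that leads to a readable number rather than another limit. The value of compound 3, > 26500 nM, is a limit of the assay. Nothing shown gives a cause for this gain in growth inhibition.

Whether an unbranched longer chain, an amine or a carboxylic acid at this same place would give a similar step remains open, since isobutoxy is the only replacement for methoxy shown here. Also open, from the compounds shown here alone, is whether isobutoxy would give a similar step on compound 2, which has ethyl in place of the bromoethyl group of compound 3.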